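This account rests on a few compounds, and the source may have more. Where it says the series, first, only, none or still open, it means among the compounds named here.

Measured in a functional assay on the whole organism with Rattus norvegicus as the target; on this read-out higher numbers stand for an effect only at larger amounts of compound and lower numbers for an effect already at smaller amounts:

- Compound 1 `CCn1c(=N)sc2cc(OC(F)(F)F)ccc21`: 5 mg/kg
- Compound 2 `CCN(CC)C(=O)Cn1c(=N)sc2cc(OC(F)(F)F)ccc21`: 9 mg/kg
- Compound 3 `CNS(=O)(=O)CCn1c(=N)sc2cc(OC(F)(F)F)ccc21`: 4 mg/kg

Compound 3, at 4 mg/kg, lies within the usual scatter of compound 1 and so cannot be ranked against it. Its number is clearly lower than that of compound 2, which stands at 9 mg/kg.

The next compound to be tested is compound 4 `N=c1sc2cc(OC(F)(F)F)ccc2n1CCS(=O)(=O)O`. It keeps the shared core and changes one end of the side chain, with hydroxy in place of methylamino on a sulfonyl sulfur.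

Within the data shown here, no measured step changes a group on a sulfonyl sulfur, so the available steps offer only indirect guidance. They do show how far this assay has moved so far when the side chain changes. There is a 1.8-fold higher number from compound 1 to compound 2 (0.26 log units; within the scatter), then a 1.3-fold lower number from compound 1 to compound 3 (0.10 log units; within the scatter), and the largest, still modest, is a 2.3-fold lower number from compound 2 to compound 3 (0.35 log units; beyond the scatter). Going by these compounds, all three changes left the numbers close together, but three compounds make a thin basis and the new group is untested here.

The estimated change is a 1.8-fold higher number from compound 3 to compound 4 (0.24 log units; within the scatter), which means no expected step beyond the scatter, with a cautious lean towards a higher number. For compound 4 the expected value is 7 mg/kg, with an estimated range of 2.5 mg/kg to 25 mg/kg.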

Compound 4, dose for half-maximal effect: > 10 mg/kg
Compound 4 gave a limit, no number (the forecaster's own chance of this, stated with the estimate: 20%); at least 1.4-fold (0.15 log units) between middle value and limit.
By their numbers in this assay, from the lowest: compounds 3, 1 and 2 (each within the scatter of the next, the first and the last beyond it). At a limit, above all of these: compound 4.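

In this assay compound 4 gives a limit rather than a number, > 10 mg/kg. On a sulfonyl sulfur, this makes hydroxy in place of methylamino a change that matters to the read-out, since the lowest size the data allow for it already lies beyond the scatter: an at least 2.5-fold higher number from compound 3 to compound 4 (0.39 log units; beyond the scatter) is the step, and it shows that the far end of this side chain is not free to vary, even though the earlier side-chain changes moved the numbers only a little. Going by these compounds, the comparisons with the other two compounds, an at least 1.1-fold higher number from compound 2 to compound 4 (0.04 log units; that floor lies within the scatter) and an at least 2.0-fold higher number from compound 1 to compound 4 (0.30 log units; that floor lies within the scatter), give floors that stay within the scatter, and their true sizes remain unknown because the reading stops at a limit: the limit of > 10 mg/kg in this assay, at which 1 of the 4 values shown sits.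

The compounds shown leave open how a carboxylic acid, an unsubstituted sulfamoyl group or a longer chain ending in the sulfo group would read in this assay. With only methylamino and hydroxy on the sulfonyl sulfur, no trend across groups at this place can yet be drawn.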